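Same Methyl Removed on Two Different Cores

The source may report more compounds than this note shows. Statements on the series, on what has been measured and on what is new or still open speak of the compounds shown alone.

Measured so far in a functional assay on HCT-116 cells (Homo sapiens) for cytotoxicity, read by sulforhodamine B assay, with stated times of 4 h and 5 days; on this read-out lower numbers stand for stronger inhibition and higher numbers for weaker inhibition:
compound 1, `COCCNS(=O)(=O)CCn1ccnc1[N+](=O)[O-]`, gives 400000 nM
compound 2, `O=[N+]([O-])c1nccn1CCS(=O)(=O)NCCO`, gives 800000 nM
compound 3, `COCCNS(=O)(=O)CCn1cnc([N+](=O)[O-])c1`, gives only a limit, told below

Compound 1 and compound 2 share one core and differ by hydrogen in place of methyl on an oxygen on a saturated carbon. On that core the step of a 2.0-fold higher number from compound 1 to compound 2 (0.30 log units; within the scatter) is small. Compound 3 carries the same atoms as compound 1 joined differently; how the two cores differ is not broken down here. For compound 3 this assay reports a limit, > 5300000 nM, as described by the limit of > 5300000 nM in this assay, at which 1 of the 3 values shown sits. Compound 4, `O=[N+]([O-])c1cn(CCS(=O)(=O)NCCO)cn1`, is not yet measured; it differs from compound 3 by hydrogen in place of methyl on an oxygen on a saturated carbon, the same change as that from compound 1 to compound 2, since the two place descriptions read alike word for word. Because the measured step of a 2.0-fold higher number from compound 1 to compound 2 (0.30 log units; within the scatter) stayed within the scatter, compound 4 is expected to stay close to compound 3, with an expected step that the limit leaves unreadable from compound 3 to compound 4. Compound 4 is therefore estimated at 8000000 nM, between 3000000 nM and 25000000 nM, most likely again reported only as a limit.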

Compound 4, half-maximal inhibitory concentration in the HCT-116 assay: 10900000 nM
Beside the measured number, compound 4's estimate is 1.4-fold (0.13 log units) below it; the measured number falls inside the stated range.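

In the HCT-116 assay compound 3 is reported only as a limit, > 5300000 nM. In the HCT-116 assay compound 4 gives 10900000 nM. Among these compounds, no step from compound 3 to compound 4 can be read there. The compounds shown leave open whether methoxy to hydroxy changes the half-maximal inhibitory concentration on the core of compound 3 as little as it does on the core of compound 1. In a physicochemical assay for solubility, read by HPLC (a lower number here means a less soluble compound, a higher number a more soluble compound), compound 3 gives 16000000 nM. In the physicochemical assay compound 4 is reported only as a limit, > 100000000 nM. In the physicochemical assay the change is an at least 6.2-fold higher number from compound 3 to compound 4 (0.79 log units; beyond the scatter).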